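This account rests on a few compounds, and the source may have more. Where it says the series, first, only, none or still open, it means among the compounds named here.

Compound 1 `C[C@H](Nc1cc(=O)oc2cc(OCc3ccccc3)ccc12)C(N)=O` is the reference point for this step. In an assay (strain Wistar) for inhibition of Amine oxidase [flavin-containing] A (Rattus norvegicus) (on this read-out lower numbers stand for stronger inhibition and higher numbers for weaker inhibition), compound 1 gives 100000 nM, the highest of the two numbers in hand. Compound 2 `NC(=O)[C@@H]1CCCN1c1cc(=O)oc2cc(OCc3ccccc3)ccc12` carries 2-carbamoylpyrrolidin-1-yl in place of (1-carbamoylethyl)amino on an aromatic carbon; in this assay compound 2 gives 99800 nM, so that a 1.0-fold lower number from compound 1 to compound 2 (0.00 log units; within the scatter). Compound 3 `NC(=O)[C@H](CO)Nc1cc(=O)oc2cc(OCc3cccc(Cl)c3)ccc12` reaches only a limit of this assay: in this assay compound 3 gives > 100000 nM, a limit and not a number. Across the three values this series is marked by the limit of > 100000 nM in this assay, at which 1 of the 3 values shown sits.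

The next compound, compound 4 `NC(=O)[C@@H]1CCCN1Cc1cc(=O)oc2cc(OCc3ccccc3)ccc12`, differs from compound 1 in one place: (2-carbamoylpyrrolidin-1-yl)methyl in place of (1-carbamoylethyl)amino on an aromatic carbon. Within the data shown here, the only measured step that bears on it is the move from the open chain to the pyrrolidine, a 1.0-fold lower number from compound 1 to compound 2 (0.00 log units; within the scatter), which kept the number within the scatter. Among the measured compounds shown here, no measured pair shows what the added methylene of the (2-carbamoylpyrrolidin-1-yl)methyl group does. The step from compound 1 to compound 4 is therefore expected to stay within the scatter, with no direction, and the estimated step in this assay is no change at the digits printed from compound 1 to compound 4 (within the scatter). For compound 4 the expected value in this assay is 100000 nM, with a range from 40000 nM to 250000 nM.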

Compound 4, half-maximal inhibitory concentration: 35000 nM
The estimate for compound 4 lay 2.9-fold (0.46 log units) above the measured number; the whole stated range lies above it.
By their numbers in this assay, from the lowest: compound 4; then compounds 2 and 1 (each within the scatter of the next).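

In this assay, the position opposite the ring oxygen now shows a step beyond the scatter: with the 2-carbamoylpyrrolidine kept, the added methylene of the (2-carbamoylpyrrolidin-1-yl)methyl group gives a 2.9-fold lower number from compound 2 to compound 4 (0.46 log units; beyond the scatter). Against the open chain the step is of the same printed size, a 2.9-fold lower number from compound 1 to compound 4 (0.46 log units; beyond the scatter), while the move to the pyrrolidine alone gives a 1.0-fold lower number from compound 1 to compound 2 (0.00 log units; within the scatter), so among these pairs the methylene, and not the pyrrolidine ring, goes with the modest change in the number. Nothing measured on these compounds accounts for this step.

The compounds shown leave open whether a methylene set in the same way on the open-chain (1-carbamoylethyl)amino group would give a similar step, and whether a longer chain, such as an ethylene between the shared core and the pyrrolidine nitrogen, would lower the number further. They also leave open whether the step depends on the carbamoyl group, which a carboxylic acid or a simple aminomethyl group in its place on the pyrrolidine would address.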